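Carrying One Substituent Swap Across Two Cores

The compounds below may be only part of what the source reports. "The series", "measured", "known", "first", "only" and "open" are said of these compounds alone.

Compound 1 `O=C(NCCNS(=O)(=O)c1ccc(-c2ccccc2OCc2cccc(O)c2)s1)Nc1cc(C(F)(F)F)cc(C(F)(F)F)c1` and compound 2 `Cc1cc(C)cc(NC(=O)NCCNS(=O)(=O)c2ccc(-c3ccccc3OCc3cccc(O)c3)s2)c1` have different cores; the difference between the two cores is not broken down here. In a functional assay on HL-60 cells (Homo sapiens) for inhibition, read by CCK-8 assay, with a stated time of 48 h (on this read-out higher numbers stand for weaker inhibition and lower numbers for stronger inhibition), compound 1 gives 4000 nM. For compound 2 the assay reports only a limit, > 20000 nM. Compound 3 `Nc1ccc(Oc2ccccc2-c2ccc(S(=O)(=O)NCCNC(=O)Nc3cc(C(F)(F)F)cc(C(F)(F)F)c3)s2)cc1` arises from compound 1 through (4-aminophenyl in place of 3-hydroxybenzyl on an oxygen on an aromatic ring). For compound 3 the result is again a limit, > 50000 nM. That change made the step of an at least 12-fold higher number from compound 1 to compound 3 (1.09 log units; beyond the scatter), which rests on the limit (the limit of > 50000 nM in this assay, at which 1 of the 3 values shown sits). Compound 4 `Cc1cc(C)cc(NC(=O)NCCNS(=O)(=O)c2ccc(-c3ccccc3Oc3ccc(N)cc3)s2)c1` carries the same change on compound 2, (4-aminophenyl in place of 3-hydroxybenzyl on an oxygen on an aromatic ring), at a place described in the same words. The expected step, set beside the earlier one, is a step that the limit leaves unreadable from compound 2 to compound 4, because compound 2 already sits at the limit (the limit of > 20000 nM in this assay, at which 1 of the 3 values shown sits). Compound 4 is therefore estimated at 60000 nM in this assay, within 20000 nM to 250000 nM, most likely reported as a limit.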

Compound 4, half-maximal inhibitory concentration: > 50000 nM
Compound 4 gave a limit, no number (the forecaster's own chance of this, stated with the estimate: 90%); the middle value does not contradict the limit.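

Compound 2 and compound 4 both gave only limits, so no step can be read between them. The compounds shown leave open whether 4-aminophenyl in place of 3-hydroxybenzyl weakens inhibition on the core of compound 2, as it does on that of compound 1.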